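Replacing the Side Chain of Compound 1 with an Aminomethylphenyl Group

A few compounds are considered here, and "the series" means these few. Any claim that something is new, unique, unknown or untested is made for them only; others in the source may bear on it.

Measured compounds:
compound 1, `c1cncc(CNCCCCN(C[C@H]2Cc3ccccc3CN2)[C@H]2CCCc3cccnc32)c1`, 15.3 nM
compound 2, `c1ccc2c(c1)CN[C@@H](CN(CCCCNCC1CCCCC1)[C@H]1CCCc3cccnc31)C2`, 158 nM
compound 3, `c1ccc2c(c1)CN[C@@H](CN(CCCCNC1CCCCC1)[C@H]1CCCc3cccnc31)C2`, 75.2 nM

In a functional assay on cells for antagonist activity at C-X-C chemokine receptor type 4 (Homo sapiens), read by fluorescence and calcium flux, with stated times of 25 min and 90 s (on this read-out higher numbers stand for weaker inhibition and lower numbers for stronger inhibition), compound 1 gives the lowest number of the three, with compound 3 nearest and compound 2 furthest. Compound 4, `NCc1ccccc1CN(C[C@H]1Cc2ccccc2CN1)[C@H]1CCCc2cccnc21`, differs from compound 1 by 2-(aminomethyl)phenyl in place of 3-(((pyridin-3-yl)methyl)amino)propyl on a saturated chain carbon bound to an amine nitrogen. Among the compounds with values here, the steps that bear on it both remove the pyridin-3-yl group: a 10-fold higher number from compound 1 to compound 2 (1.01 log units; beyond the scatter) and a 4.9-fold higher number from compound 1 to compound 3 (0.69 log units; beyond the scatter), both weakening. Compound 4 also loses that ring, though it keeps an amine on a shorter group, so a weakening of modest size is expected, a 3.9-fold higher number from compound 1 to compound 4 (0.59 log units; beyond the scatter). Compound 4 is thus estimated at 60 nM in this assay, within a range of 12 nM to 300 nM.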

Compound 4, half-maximal inhibitory concentration: 50.8 nM
Estimate against measurement, compound 4: 1.2-fold (0.07 log units) above, within the range that was stated.
By their numbers in this assay, from the lowest: compound 1; then compounds 4 and 3 (each within the scatter of the next); then compound 2.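

In this assay the 2-(aminomethyl)phenyl group does less well than the side chain of compound 1, with a 3.3-fold higher number from compound 1 to compound 4 (0.52 log units; beyond the scatter) as the measure, yet it matches the cyclohexyl amine, with a 1.5-fold lower number from compound 3 to compound 4 (0.17 log units; within the scatter) as the reading, and does better than the cyclohexylmethyl amine, with a 3.1-fold lower number from compound 2 to compound 4 (0.49 log units; beyond the scatter) as the reading. The amine on this saturated chain carbon therefore need not sit on a propyl chain to give a number in this range. No evidence is available to explain these differences. The compounds shown leave open whether a pyridine ring bearing the aminomethyl group, or a longer chain ending in an amine on the phenyl ring, would recover the number of compound 1.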